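A few compounds are considered here, and "the series" means these few. Any claim that something is new, unique, unknown or untested is made for them only; others in the source may bear on it.

Measured so far in a functional assay on DU-145 cells (Homo sapiens) for inhibition, read by MTT assay, with a stated time of 24 h; on this read-out lower numbers stand for stronger inhibition and higher numbers for weaker inhibition:
compound 1, `CCOC(=O)C1=Cc2ccccc2OC1(OCc1cn(CC(=O)Nc2ccc(C)cc2)nn1)C(F)(F)F`, gives > 150000 nM, which is a limit of the assay.
compound 2, `CCOC(=O)C1=Cc2ccccc2OC1(OCc1cn(CC(=O)Nc2ccccc2F)nn1)C(F)(F)F`, gives 33900 nM.
compound 3, `CCOC(=O)C1=Cc2ccccc2OC1(OCc1cn(-c2ccccc2)nn1)C(F)(F)F`, gives > 150000 nM, which is again a limit of the assay.

Compound 3 therefore stands at the limit (the limit of > 150000 nM in this assay, at which 2 of the 3 values shown sit), so for it no number is known, only that it sits at or beyond that bound. The step to compound 4, `CCOC(=O)C1=Cc2ccccc2OC1(OCc1cn(-c2ccc(F)c(Cl)c2)nn1)C(F)(F)F`, is 3-chloro-4-fluorophenyl in place of phenyl on an aromatic nitrogen.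

For the measured compounds named here, none of the measured steps touches this position in this way. The step of an at least 4.4-fold lower number from compound 1 to compound 2 (0.64 log units; beyond the scatter) concerns a substituent on the amide-type nitrogen, not on the aromatic nitrogen. The step of an at least 4.4-fold higher number from compound 2 to compound 3 (0.64 log units; beyond the scatter) and the step that the two limits leave unreadable from compound 1 to compound 3 both exchange the entire group on the aromatic nitrogen, so they show that a bare phenyl there sits at the limit, but not how a substituted phenyl would compare with it.

Going by the values given here, with compound 3 already at the limit and no measured step speaking to the change, the account expects compound 4 to stay weak, with a fair chance that the assay again reports only a limit. Compound 4 is estimated at 100000 nM, within a range from 20000 nM to 300000 nM. That estimate means an expected at least 1.5-fold lower number from compound 3 to compound 4 (0.17 log units; that floor lies within the scatter).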

Compound 4, half-maximal inhibitory concentration: 21500 nM
Estimate against measurement, compound 4: 4.7-fold (0.67 log units) above, and the stated range covers the measured number.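

In this assay, 3-chloro-4-fluorophenyl in place of phenyl on the aromatic nitrogen is the first change shown that keeps a phenyl ring directly on that nitrogen and alters only what the ring carries, and it brings the number down off the limit (an at least 6.9-fold lower number from compound 3 to compound 4 (0.84 log units; beyond the scatter)). Compound 3 holds only a limit, so this step has a floor and no exact size, because the assay gives no number for that compound: the limit of > 150000 nM in this assay, at which 2 of the 4 values shown sit. The 3-chloro-4-fluorophenyl group on this nitrogen also reads level with the ((2-fluorophenyl)carbamoyl)methyl group (a 1.6-fold lower number from compound 2 to compound 4 (0.20 log units; within the scatter)) and stands clearly apart from the ((4-methylphenyl)carbamoyl)methyl group (an at least 6.9-fold lower number from compound 1 to compound 4 (0.84 log units; beyond the scatter)), so a directly attached ring can match the better of the two amide-bearing groups shown.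

The compounds shown leave open whether the chlorine, the fluorine or only the two together carry the step, since they appear here only as a pair. Also open, as far as these compounds go, is how an amine or a carboxylic acid on that phenyl ring would read, and whether any group at this position can go well beyond the level that compound 2 and compound 4 share.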